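Adding a methyl to the hydroxy group of compound 1

This account rests on a few compounds, and the source may have more. Where it says the series, first, only, none or still open, it means among the compounds named here.

Compound 1 `O=C(NCCCNc1cc(-c2cn(-c3ccccc3)nc2-c2cccc(O)c2)ccn1)Nc1ccc(F)cc1` gives 20300 nM
Compound 2 `O=C(NCCCNc1cc(-c2cn(-c3ccccc3)nc2-c2cccc(O)c2)ccn1)Nc1cccc(C(F)(F)F)c1` gives 13200 nM

Within the data shown here, in a functional assay on TK-10 cells (Homo sapiens) for antiproliferative activity, read by sulforhodamine B assay, with a stated time of 48 h (on this read-out lower numbers stand for stronger inhibition of growth and higher numbers for weaker inhibition of growth), compound 1 gives 20300 nM and stands level with compound 2, the only other compound measured. Among the measured compounds shown here, the one measured step is a 1.5-fold lower number from compound 1 to compound 2 (0.19 log units; within the scatter) and it lies elsewhere on the molecule, on an amide-type nitrogen. Compound 3 `COc1cccc(-c2nn(-c3ccccc3)cc2-c2ccnc(NCCCNC(=O)Nc3ccc(F)cc3)c2)c1` differs from compound 1 by methyl in place of hydrogen on an oxygen on an aromatic ring which turns hydroxy into methoxy. For the measured compounds named here, no measured step tests this change, so no shift beyond the scatter is expected. The estimated 1.1-fold higher number from compound 1 to compound 3 (0.03 log units; within the scatter) is therefore small. In this assay compound 3 is expected at 22000 nM with 9000 nM to 55000 nM as its range.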

Compound 3, concentration for total growth inhibition: > 37000 nM
Compound 3 was reported as a limit; the forecaster's own chance of this, stated with the estimate: 15%; at least 1.6-fold (0.22 log units) between middle value and limit.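

In this assay, among these compounds, the first reading at this oxygen, turning 3-hydroxyphenyl into 3-methoxyphenyl, gives an at least 1.8-fold higher number from compound 1 to compound 3 (0.26 log units; that floor lies within the scatter) and so shows no gain in growth inhibition from the added methyl. On these data alone, the true size of the change stays unknown. Compound 3 carries a limit and not a number: the limit of > 37000 nM in this assay, at which 1 of the 3 values shown sits.

As far as these compounds go, whether an amine or a longer chain such as ethoxy would read differently at this place stays open. So does whether the same change acts alike on compound 2, with its 3-(trifluoromethyl)phenyl group.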